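Moving the bromo group: from compound 2 to compound 3

The source may report more compounds than this note shows. Statements on the series, on what has been measured and on what is new or still open speak of the compounds shown alone.

In a toxicity assay on HaCaT cells (Homo sapiens) for cytotoxicity, read by CCK-8 assay, with a stated time of 24 h (a lower number here means that less compound is tolerated, a higher number that more compound is tolerated), compound 1 (`COc1ccccc1Oc1c(N)nc(-c2cccc(F)c2)nc1Cl`) gives 17000 nM as its reading, and compound 2 (`COc1ccccc1Oc1c(N)nc(-c2cccc(Br)c2)nc1Cl`) gives 16100 nM as its reading. Going by the values given here, these are the only two numbers so far, and compound 2 stands level with compound 1, within the usual scatter of repeat measurements.

Compound 3 (`COc1ccccc1Oc1c(N)nc(-c2ccc(Br)cc2)nc1Cl`) has the same atoms as compound 2, joined differently. It carries 4-bromophenyl in place of 3-bromophenyl on an aromatic carbon and leaves the rest of the molecule unchanged.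

Among the compounds with values here, only one measured step offers any guidance. Putting bromo in place of fluoro gave a 1.1-fold lower number from compound 1 to compound 2 (0.02 log units; within the scatter) as its result, which shows little movement on that ring. That step changes the halogen, though, not where it sits, so no measurement tests this kind of change directly.

On this thin evidence, the expected step is a 1.0-fold lower number from compound 2 to compound 3 (0.00 log units; within the scatter) and no shift beyond the scatter is expected in either direction. For compound 3 the estimated value is 16000 nM with an expected range from 8000 nM to 35000 nM in this test.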

Compound 3, half-maximal cytotoxic concentration: 58600 nM
For compound 3 the middle estimate is 3.7-fold (0.56 log units) below the measured one; measured number above the stated range.
By their numbers in this assay, from the lowest: compounds 2 and 1 (each within the scatter of the next); then compound 3.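

In this assay, where the bromo group sits on the phenyl ring counts for more than the earlier change of halogen: going from 3-bromophenyl to 4-bromophenyl gives a 3.6-fold higher number from compound 2 to compound 3 (0.56 log units; beyond the scatter) and so takes the reading beyond the scatter, while replacing fluoro with bromo gave only a 1.1-fold lower number from compound 1 to compound 2 (0.02 log units; within the scatter) and stayed within it. Compound 3 also separates from the fluoro compound, with a 3.4-fold higher number from compound 1 to compound 3 (0.54 log units; beyond the scatter) as the printed step, although that comparison changes both the halogen and its place, so it cannot be credited to either change alone. A higher number in this test means that more compound is tolerated by the cells, so 4-bromophenyl is the best tolerated of these three rings, but no measurement at hand explains why moving the bromo group has this effect. The compounds shown leave open whether a fluoro group placed as the bromo group is in 4-bromophenyl would give a similar rise, or whether the rise belongs to bromo alone. They also leave open how an amine or a carboxylic acid would read at that place on the ring.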